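The source may report more compounds than this note shows. Statements on the series, on what has been measured and on what is new or still open speak of the compounds shown alone.

Three compounds were measured in a functional assay for inhibition of sodium/hydrogen exchanger (Oryctolagus cuniculus); a lower number here means a stronger inhibitor, a higher number a weaker inhibitor. Compound 2, `Cc1cc(C)c(S(C)(=O)=O)cc1C(=O)N=C(N)N`, gives 11 nM. Compound 1, `Cc1cc(Cl)c(S(C)(=O)=O)cc1C(=O)N=C(N)N`, gives 25 nM; the two differ by chloro in place of methyl on an aromatic carbon, and the step is a 2.3-fold higher number from compound 2 to compound 1 (0.36 log units; beyond the scatter). Compound 3, `Cc1cc(Nc2ncccn2)c(S(C)(=O)=O)cc1C(=O)N=C(N)N`, gives 8.3 nM; its core differs from that of compound 2 by (pyrimidin-2-yl)amino in place of methyl on an aromatic carbon, and the step is a 1.3-fold lower number from compound 2 to compound 3 (0.12 log units; within the scatter). From compound 1 to compound 3 the step is a 3.0-fold lower number from compound 1 to compound 3 (0.48 log units; beyond the scatter).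

Compound 4, `CS(=O)(=O)c1cc(C(=O)N=C(N)N)c(Cl)cc1Nc1ncccn1`, has not yet been measured in this assay. It differs from compound 3 by chloro in place of methyl on an aromatic carbon. Among the measured compounds shown here, this is the same kind of change as the one from compound 2 to compound 1, but not the same: there the place was ortho to a methylsulfonyl group, meta to a methyl group and para to a group of 6 heavy atoms, whereas here it is ortho to a group of 6 heavy atoms, meta to a (pyrimidin-2-yl)amino group and para to a methylsulfonyl group. Among the compounds shown, the change occurs twice.

For the measured compounds named here, the expectation for compound 4 rests on compound 3 and on the one earlier example of this kind of change, where compound 1 gives 25 nM against compound 2; the step from compound 3 to compound 4 is estimated at a 2.2-fold higher number from compound 3 to compound 4 (0.34 log units; beyond the scatter). With the place differing, compound 4 is expected to give 18 nM in this assay, somewhere between 8 nM and 45 nM.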

Compound 4, half-maximal inhibitory concentration: 49 nM
Compound 4: middle estimate off by 2.7-fold (0.43 log units), on the low side; measured number above the stated range.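

In this assay, chloro in place of methyl on an aromatic carbon gives a higher number on the core of compound 3, with a 5.9-fold higher number from compound 3 to compound 4 (0.77 log units; beyond the scatter), and the same kind of change also gave a higher number on the core of compound 2, with a 2.3-fold higher number from compound 2 to compound 1 (0.36 log units; beyond the scatter). Set side by side, the two steps run the same way and their sizes cannot be told apart: the same change on two cores in this assay, a 2.3-fold higher number (0.36 log units; beyond the scatter) from compound 2 to compound 1 and a 5.9-fold higher number (0.77 log units; beyond the scatter) from compound 3 to compound 4, 2.6-fold (0.41 log units) apart, within the scatter of two such steps. Among the compounds shown here, this shows that the direction of the change carried over between these two cores, but it does not show that the size is fixed or that the direction would hold on any further core, and with only two pairs, the effect of the core cannot be separated from that of the place, which in compound 4 is ortho to a group of 6 heavy atoms and para to a methylsulfonyl group.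

The compounds shown leave open how other groups would behave at this place on the core of compound 3, such as fluoro, methoxy or an amine. They also leave open whether the step would look the same if the (pyrimidin-2-yl)amino group gave way to a phenylamino group.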